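Swapping methylsulfanyl for methylsulfonyl in a mouse antagonist test

This account rests on a few compounds, and the source may have more. Where it says the series, first, only, none or still open, it means among the compounds named here.

Compound 1 `Cn1c(-c2ccccc2)nnc1S(C)(=O)=O`: 12.8 mg/kg
Compound 2 `CSc1nnc(-c2cccc3ccccc23)n1C`: > 200 mg/kg

Both results come from a functional assay on the whole organism for antagonist activity, with Mus musculus as the target; on this read-out lower numbers stand for an effect already at smaller amounts and higher numbers for an effect only at larger amounts of compound. Compound 2 is reported only as a limit of the assay, > 200 mg/kg, so it has no exact value of its own.

Compound 3 `Cn1c(-c2cccc3ccccc23)nnc1S(C)(=O)=O` keeps the core and the large group of compound 2 and alters one group: methylsulfonyl in place of methylsulfanyl on an aromatic carbon. In words, this is methylsulfonyl in place of methylsulfanyl on an aromatic carbon. Compound 3 thereby shares methylsulfonyl with compound 1, while the two differ in the large group. Among the compounds with values here, no measured pair shows this swap alone, so the size of the step remains uncertain.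

Because compound 1 carries methylsulfonyl and reads 12.8 mg/kg, a step toward lower numbers, beyond the usual scatter, is expected in this assay. A second result at the limit remains possible. The estimated change is an at least 5.7-fold lower number from compound 2 to compound 3 (0.75 log units; beyond the scatter). For compound 3 the expected value is 35 mg/kg, with an estimated range from 8 mg/kg to 150 mg/kg.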

Compound 3, dose for half-maximal effect: > 200 mg/kg
Compound 3: no number, only a limit; the forecaster's own chance of this, stated with the estimate: 25%; middle value at least 5.7-fold (0.75 log units) away from the limit.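

In this assay, compound 2 and compound 3 are both reported only as limits, so the swap of methylsulfanyl for methylsulfonyl between them cannot be read as a step: the limit of > 200 mg/kg in this assay, at which 2 of the 3 values shown sit.

The compounds shown leave open whether methylsulfonyl in place of methylsulfanyl changes the result at all when this large group is present.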